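The compounds below may be only part of what the source reports. "The series", "measured", "known", "first", "only" and "open" are said of these compounds alone.

Measured compounds:
- compound 1, `CN(C)C(=O)c1cc2cnc(Nc3ccc(S(=O)(=O)NCCCCN=C=S)cc3)nc2n1C1CCCC1`: 72.7%
- compound 2, `CN(C)C(=O)c1cc2cnc(Nc3ccc(C(=O)NCCCCN=C=S)cc3)nc2n1C1CCCC1`: 74.2%
- compound 3, `CN(C)C(=O)c1cc2cnc(Nc3ccc(NC(=O)CCCCCN=C=S)cc3)nc2n1C1CCCC1`: 85%

In a functional assay on NCI-H1299 cells (Homo sapiens) for inhibition, read by CCK-8 assay, with a stated time of 72 h, tested at 10 uM (on this read-out higher numbers stand for a stronger effect at the one concentration tested and lower numbers for a weaker effect), compound 3 stands highest of the three numbers. Its margin over the others is a number 12.3 percentage points higher from compound 1 to compound 3 (beyond the scatter) and a number 10.8 percentage points higher from compound 2 to compound 3 (beyond the scatter), both beyond the scatter, whereas compound 1 and compound 2 sit within the scatter of each other, a number 1.5 percentage points higher from compound 1 to compound 2 (within the scatter).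

Compound 4, `CN(C)C(=O)c1cc2cnc(Nc3ccc(NC(=O)CCCCCCN=C=S)cc3)nc2n1C1CCCC1`, differs from compound 3 by a group of 4 heavy atoms (2 carbon, 1 nitrogen, 1 sulfur; no ring) in place of a group of 3 heavy atoms (1 carbon, 1 nitrogen, 1 sulfur; no ring), on a saturated chain carbon, five bonds along the chain from a carbonyl carbon. All three measured steps exchange whole groups on an aromatic carbon; none of them lengthens or shortens a saturated chain, so none bears directly on this change. Within the data shown here, with no measured step of this kind, the working expectation is a step in this assay of no clear direction and within the scatter, with compound 3 as the anchor for compound 4.

For compound 4 the expected value in this assay is 84%, with a range from 70% to 95%. This corresponds to an expected step of a number 1 percentage points lower from compound 3 to compound 4 (within the scatter).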

Compound 4, a percentage reported as inhibition, at one concentration (the size of the read-out at that concentration, not a potency): 80.9%
The estimate for compound 4 lay 3.1 percentage points above the measured number; the range from low to high includes it.
By their numbers in this assay, from the lowest: compounds 1, 2, 4 and 3 (each within the scatter of the next, the first and the last beyond it).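

On a saturated chain carbon, five bonds along the chain from a carbonyl carbon, a group of 4 heavy atoms in place of a group of 3 heavy atoms gives in this assay a step of a number 4.1 percentage points lower from compound 3 to compound 4 (within the scatter), so this position accepts the change without a step beyond the scatter. The margin compound 3 holds over the two shorter-linked compounds does not carry over to compound 4, with a number 6.7 percentage points higher from compound 2 to compound 4 (within the scatter) and a number 8.2 percentage points higher from compound 1 to compound 4 (within the scatter) as the steps from those compounds. No measurement shown gives a reason for these numbers.

From the compounds shown here alone, whether a longer chain, or an amine or a carboxylic acid in place of the group of 3 heavy atoms, would keep the number in this assay stays open. Each compound has a reading at only one concentration, and these readings speak only of a stronger or weaker effect at that concentration.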